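The compounds below may be only part of what the source reports. "The series", "measured", "known", "first", "only" and "open" are said of these compounds alone.

Measured so far: compound 1 `O=C(O)Cn1nc(Cc2nc3cc(Cl)c(OCC(F)F)cc3[nH]2)c2ccccc2c1=O`, 1.97; compound 2 `CCOc1cc2[nH]c(Cc3nn(CC(=O)N4CCOCC4)c(=O)c4ccccc34)nc2cc1Cl`, 3.32; compound 3 `COc1cc(OC)c(NC(=O)Cc2cn(CC(=O)O)c3ccccc23)cc1Cl`, 2.13.

In a physicochemical assay for lipophilicity, at pH 7.4 (on this read-out lower numbers stand for lower lipophilicity and higher numbers for higher lipophilicity), compound 2 gives 3.32, the highest of the three values, beyond the scatter above both compound 3 and compound 1. Compound 4 `CCOc1cc2[nH]c(Cc3nn(CC(=O)O)c(=O)c4ccccc34)nc2cc1Cl` has not yet been measured. It differs from compound 2 in one place: hydroxy in place of morpholin-4-yl on a carbonyl carbon. Among the measured compounds shown here, no step between measured compounds covers this change directly. A large fall in this assay is nonetheless expected, well beyond the scatter, because compound 1 gives 1.97 while carrying the same carboxymethyl group on a closely related core. The expected step from compound 2 to compound 4 is a number 1.22 log units lower from compound 2 to compound 4 (beyond the scatter). Compound 4 is therefore estimated at 2.1, with a range of 1.6 to 2.7.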

Compound 4, distribution coefficient: 1.8
Beside the measured number, compound 4's estimate is 0.30 log units above it; the measured number falls inside the stated range.
By their numbers in this assay, from the lowest: compounds 4, 1 and 3 (each within the scatter of the next, the first and the last beyond it); then compound 2.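

In this assay, hydroxy in place of morpholin-4-yl on a carbonyl carbon now has a direct reading (a number 1.52 log units lower from compound 2 to compound 4 (beyond the scatter)), a large step at this position. With the carboxymethyl group present, methyl in place of difluoromethyl on a saturated chain carbon bound to an oxygen on an aromatic ring reads as a number 0.17 log units lower from compound 1 to compound 4 (within the scatter) and so does not separate the two compounds. No measured property bears on the cause of either step.

Still open, on these data alone, is where a dimethylamino group or a piperazin-1-yl group on this carbonyl carbon would fall relative to compound 2 and compound 4. Also open, as far as these compounds go, is whether the step keeps its size with difluoromethyl on the chain.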